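Methyl for fluoro on the cinnamoyl aryl ring

The source may report more compounds than this note shows. Statements on the series, on what has been measured and on what is new or still open speak of the compounds shown alone.

Two compounds have numbers in an ADME assay on Vero cells (Chlorocebus sabaeus) for cytotoxicity, read by WST assay, tested at 100 ug/mL (a higher number here means a weaker effect of the compound at the concentration tested, a lower number a stronger effect), so far. Compound 1 `COC(=O)[C@H](CO)NC(=O)/C=C/c1ccc(C)cc1` gives 101% in this assay. Within the data shown here, compound 2 `O=C(/C=C/c1ccc(F)cc1)O/C(=N/C1CCCCC1)NC1CCCCC1` gives 85.5%, the lowest of the two numbers; compound 1, its only neighbour, lies higher by a margin beyond the scatter, though the two share no single-point change and so their gap is only what the two values show.

Compound 3 `Cc1ccc(/C=C/C(=O)O/C(=N/C2CCCCC2)NC2CCCCC2)cc1` has not yet been measured. It differs from compound 2 in one place: methyl in place of fluoro on an aromatic carbon. The exchange takes place on an aromatic carbon of a six-membered aromatic ring of carbon only, para to a large group, with the rest of the molecule unchanged.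

Among the measured compounds shown here, no measured pair in this set isolates this exchange, so the size of the step rests on judgement alone. Compound 3 is expected to come out close to compound 2, with a step of a number 4.5 percentage points higher from compound 2 to compound 3 (within the scatter) that stays within the usual scatter. The estimate for compound 3 in this assay is 90%, with a range from 72% to 105%.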

Compound 3, a percentage reported as activity, at one concentration (the size of the read-out at that concentration, not a potency): 95.5%
Estimate against measurement, compound 3: 5.5 percentage points below; low and high end bracket the measured number.
By their numbers in this assay, from the lowest: compounds 2, 3 and 1 (each within the scatter of the next, the first and the last beyond it).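

Among these compounds, the exchange of fluoro for methyl, on an aromatic carbon para to a large group, gives the first change in one place that can be read in this assay, and it comes to a number 10 percentage points higher from compound 2 to compound 3 (within the scatter) with the rest of the molecule unchanged. At this position and at the single concentration tested, the two groups therefore cannot be told apart, so 4-fluorophenyl and 4-methylphenyl read alike as far as this one pair can show. Nothing available bears on how either group acts at this carbon, and this single pair gives no account of the reading.

The compounds shown leave open whether a methoxy group, a carboxylic acid or an amine on this same aromatic carbon would also stay within the scatter of compound 2 in this assay. They also leave open whether the exchange of fluoro for methyl would give a step of similar size on the core of compound 1, which carries the methyl group but has no fluoro partner here.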